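The source may hold more compounds than are shown below. What is called first, only, known or untested is meant among the compounds shown, and "the series" means these compounds.

Measured compounds:
compound 1 `COC(=O)[C@@]1(C)CCC=C2[C@@H]1CC[C@@H](C)[C@]2(C)Cc1c[nH]c2ccccc12`: 4500 nM
compound 2 `COC(=O)[C@@]1(C)CCC=C2[C@@H]1CC[C@@H](C)[C@]2(C)Cc1c[nH]c2ccc(C)cc12`: 18000 nM
compound 3 `COC(=O)[C@@]1(C)CCC=C2[C@@H]1CC[C@@H](C)[C@]2(C)Cc1c[nH]c2ccc(Br)cc12`: 16000 nM

In a functional assay on HBL-100 cells (Homo sapiens) for inhibition, read by sulforhodamine B assay, with a stated time of 48 h (a higher number here means a weaker inhibitor of growth, a lower number a stronger inhibitor of growth), compound 1 stands lowest of the three numbers. The nearest number lies a 3.6-fold higher number from compound 1 to compound 3 (0.55 log units; beyond the scatter) and the furthest a 4.0-fold higher number from compound 1 to compound 2 (0.60 log units; beyond the scatter). The two substituted compounds are close to one another, a 1.1-fold lower number from compound 2 to compound 3 (0.05 log units; within the scatter).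

Compound 4 `COC(=O)[C@@]1(C)CCC=C2[C@@H]1CC[C@@H](C)[C@]2(C)Cc1c[nH]c2c(C)cccc12` differs from compound 1 by methyl in place of hydrogen on an aromatic carbon. Among the measured compounds shown here, no measured pair shows exactly this placement of a methyl. For the measured compounds named here, the steps that bear on it are the two substitutions on the same carbon-only ring of the shared core: a 4.0-fold higher number from compound 1 to compound 2 (0.60 log units; beyond the scatter) and a 3.6-fold higher number from compound 1 to compound 3 (0.55 log units; beyond the scatter), each a modest rise beyond the scatter. Both a methyl and a bromo at their position raised the number by a similar amount, so a substituent at the new position is expected also to weaken growth inhibition, though the different position makes the size uncertain. The expected step is a 2.7-fold higher number from compound 1 to compound 4 (0.43 log units; beyond the scatter). For compound 4 the estimate in this assay is 12000 nM, with a range from 4000 nM to 36000 nM.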

Compound 4, concentration for 50% growth inhibition: 8000 nM
Compound 4: middle estimate off by 1.5-fold (0.18 log units), on the high side; the measured number falls inside the stated range.
By their numbers in this assay, from the lowest: compounds 1, 4, 3 and 2 (each within the scatter of the next, the first and the last beyond it).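

In this assay, methyl on the aromatic carbon ortho to a fused ring and meta to a fused ring gives a 1.8-fold higher number from compound 1 to compound 4 (0.25 log units; within the scatter) and so leaves no readable separation from the unsubstituted compound. Methyl at the other placement gives a 4.0-fold higher number from compound 1 to compound 2 (0.60 log units; beyond the scatter) and does separate, so among the compounds shown the placement of the methyl decides whether the step can be read, and the earlier rise does not carry over to this position. No measurement at hand accounts for this difference between the two placements.

Open, on these data alone, is whether a bromo on this same carbon would also stay within the scatter. Also open, as far as these compounds go, is whether a methoxy, an amine or a longer chain there would give a step beyond it.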